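A Fluorine Added to a Weakly Cytotoxic Scaffold

A few compounds are considered here, and "the series" means these few. Any claim that something is new, unique, unknown or untested is made for them only; others in the source may bear on it.

Compound 1 `Cn1ccc2c(Oc3ccc(NC(=O)c4nn(-c5ccc(Br)cc5F)ccc4=O)cc3)ccnc21` and compound 2 `Cn1ccc2c(Oc3ccc(NC(=O)c4nn(-c5ccc(Br)cc5F)ccc4=O)cc3F)ccnc21` share one core, while compound 3 `Cc1cc(=O)n(-c2ccccc2OC(F)(F)F)nc1C(=O)Nc1ccc(Oc2ncnc3c2ccn3C)cc1` and the not yet measured compound 4 `Cc1cc(=O)n(-c2ccccc2OC(F)(F)F)nc1C(=O)Nc1ccc(Oc2ncnc3c2ccn3C)c(F)c1` share another; the difference between the two cores is not broken down here. In a functional assay on A549 cells (Homo sapiens) for cytotoxicity, read by MTT assay, with a stated time of 72 h (a lower number here means a stronger inhibitor, a higher number a weaker inhibitor), compound 1 gives 35700 nM, and compound 2 gives 26800 nM. The change between them, (fluoro in place of hydrogen on an aromatic carbon), brought a 1.3-fold lower number from compound 1 to compound 2 (0.12 log units; within the scatter). In this assay compound 3 gives 25200 nM, a number sitting among the other two within the usual scatter, so no order among the three can be read. Compound 4 carries the same change, (fluoro in place of hydrogen on an aromatic carbon), made on its own core, and the surroundings of the place are described in the same words for both pairs. Among the compounds with values here, the earlier step of a 1.3-fold lower number from compound 1 to compound 2 (0.12 log units; within the scatter) stayed within the scatter, and that is the only guide available here. On that basis the step estimated for compound 4 is a 1.1-fold lower number from compound 3 to compound 4 (0.06 log units; within the scatter). The value expected for compound 4 in this assay is 22000 nM, with a plausible range from 10000 nM to 50000 nM.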

Compound 4, half-maximal inhibitory concentration: > 60000 nM
Compound 4 ended at the assay's limit; the forecaster's own chance of this, stated with the estimate: 5%; middle value at least 2.7-fold (0.43 log units) from the limit.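

In this assay, putting fluoro in place of hydrogen on an aromatic carbon of the core of compound 3 gave an at least 2.3-fold higher number from compound 3 to compound 4 (0.37 log units; beyond the scatter), a step beyond the scatter and the reverse in direction of what the estimate suggested. As far as these compounds go, compound 4 gives > 60000 nM, which is a limit of the assay and not a number, so the step has only a lower bound and its full size stays unknown. The same change therefore did not carry over unchanged from the core of compound 1 to the core of compound 3, although two pairs cannot show why, nor how it would behave on a third core: the same change on two cores in this assay, a 1.3-fold lower number (0.12 log units; within the scatter) from compound 1 to compound 2 and an at least 2.3-fold higher number (0.37 log units; beyond the scatter) from compound 3 to compound 4, at least 3.1-fold (0.50 log units) apart, beyond the scatter of two such steps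

From the compounds shown here alone, whether a chloro, methyl or methoxy group on that same aromatic carbon would track hydrogen or fluoro on either core remains open. Also open, going by these compounds, is whether a different group on the ring carrying the trifluoromethoxy group would alter the effect of the fluoro.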